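The compounds below may be only part of what the source reports. "The series", "measured", "known", "first", "only" and "open" are said of these compounds alone.

Within the data shown here, in a functional assay on FM3A cells (Mus musculus) for cytotoxicity (on this read-out higher numbers stand for an effect only at larger amounts of compound and lower numbers for an effect already at smaller amounts), compound 1 `COOC1(OOCCCCCCI)CCCCCCCCCCC1` gives 86000 nM, the higher of the two numbers known so far, while compound 2 `COOC1(OOCCCCCCOC2CCOCC2)CCCCCCCCCCC1` gives 7600 nM. Among the measured compounds shown here, the one measured step, an 11-fold lower number from compound 1 to compound 2 (1.05 log units; beyond the scatter), puts (oxan-4-yl)oxy in place of iodo on a saturated chain carbon, six bonds along the chain from an oxygen. Compound 3 `COOC1(OOCCC(=O)OC)CCCCCCCCCCC1` differs from compound 1 by methoxycarbonyl in place of 4-iodobutyl on a saturated chain carbon, two bonds along the chain from an oxygen. The step to compound 2 bears on this only in part: it too removes the iodine, but it keeps the chain and brings in (oxan-4-yl)oxy, whereas compound 3 loses 4-iodobutyl and brings in methoxycarbonyl. A step of the size seen to compound 2 is therefore not assured in this assay, and a smaller drop is expected, a 2.5-fold lower number from compound 1 to compound 3 (0.39 log units; beyond the scatter). Compound 3 is estimated at 35000 nM, within a range from 8000 nM to 120000 nM.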

Compound 3, half-maximal effective concentration: 1400 nM
Compound 3: the middle estimate sits 25-fold (1.40 log units) above what was measured; measured number below the stated range.
By their numbers in this assay, from the lowest: compound 3; then compound 2; then compound 1.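

In this assay, a 61-fold lower number from compound 1 to compound 3 (1.79 log units; beyond the scatter) is a step larger than an 11-fold lower number from compound 1 to compound 2 (1.05 log units; beyond the scatter), so at this place, on a saturated chain carbon, two bonds along the chain from an oxygen, the drop in the number is not tied to keeping the chain. Among these compounds, compound 1 had so far been compared only with a compound that kept the chain and lost the iodine, whereas compound 3 shows that the whole 4-iodobutyl can give way to methoxycarbonyl and the effect still appears at smaller amounts. Nothing measured here accounts for the size of this step. Going by these compounds, the change removes 4-iodobutyl and brings in methoxycarbonyl in a single move, so the share of each remains open. On these data alone, whether a carboxylic acid at this place, or a longer chain ending in methoxycarbonyl, would follow compound 3 also remains open.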